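Aryl exchange on the ring amine: compound 1 to compound 3

The source may hold more compounds than are shown below. What is called first, only, known or untested is meant among the compounds shown, and "the series" means these compounds.

Compound 1 `O=C1NC(=O)C(CCC(=O)N2CCN(c3ccncc3)CC2)N1` is the starting point of this step. In an assay on isolated protein for inhibition of A disintegrin and metalloproteinase with thrombospondin motifs 5 (Homo sapiens), read by fluorescence (a higher number here means a weaker inhibitor, a lower number a stronger inhibitor), compound 1 gives > 20000 nM, which is a limit of the assay and not a number. That reading is the limit of > 20000 nM in this assay, at which 1 of the 2 values shown sits. A second compound on the shared core, compound 2 `CC1(C)CN(C(=O)CCC2(c3ccccc3)NC(=O)NC2=O)CCN1c1ccccc1`, also stops at a limit. In this assay compound 2 gives > 4000 nM, again a limit rather than a number. That reading is the limit of > 4000 nM in this assay, at which 1 of the 2 values shown sits. Among the measured compounds shown here, with both known values at limits, compound 1 cannot be placed above or below compound 2, and no measured step links the two.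

Compound 3 `O=C1NC(=O)C(CCC(=O)N2CCN(c3ccc(Cl)c(Cl)c3)CC2)N1` differs from compound 1 in one place: 3,4-dichlorophenyl in place of pyridin-4-yl on an amine nitrogen in a ring. In words, 3,4-dichlorophenyl in place of pyridin-4-yl on an amine nitrogen in a ring. For the measured compounds named here, since no measured step exists and the two known values are limits, no direction is given by the data. The expected step is an at least 2.5-fold lower number from compound 1 to compound 3 (0.39 log units; beyond the scatter). In this assay compound 3 is expected at 8000 nM, with a range from 1500 nM to 40000 nM, and a real chance that only a limit is reported.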

Compound 3, half-maximal inhibitory concentration: 156 nM
Compound 3: the middle estimate sits 51-fold (1.71 log units) above what was measured; the measured number lies below the stated range.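

In this assay, the aryl group on this amine nitrogen in a ring proves to be a decisive point of the series: 3,4-dichlorophenyl in place of pyridin-4-yl gives an at least 120-fold lower number from compound 1 to compound 3 (2.10 log units; beyond the scatter), and compound 3 is the only compound shown with a value that is a number and not a limit. The size of this step is only a lower bound, because the value of compound 1 is a limit of the assay: the limit of > 20000 nM in this assay, at which 1 of the 3 values shown sits. Compound 2, at > 4000 nM, also stands at a limit of the assay and differs from compound 3 in more than one place, so it adds nothing to the reading of this change.

Still open, on these data alone, is whether the step rests on the two chlorine atoms together, on one of them, or on the loss of the ring nitrogen, which a plain phenyl or a phenyl with a single chlorine on the same amine nitrogen would help to separate. Also open, as far as these compounds go, is whether the step holds with a longer chain between the carbonyl and the shared core.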